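Swapping dimethylamino for amino on a cyclohexane amide

This account rests on a few compounds, and the source may have more. Where it says the series, first, only, none or still open, it means among the compounds named here.

Of the compounds shown here, three sharing a core have been measured in an assay on isolated protein for inhibition of Rho-associated protein kinase 2 (Homo sapiens); a lower number here means a stronger inhibitor, a higher number a weaker inhibitor. Compound 1, `CN(C)[C@H]1CC[C@@H](C(=O)Nc2cc3cc[nH]c(=O)c3cc2Cl)CC1`, carries a dimethylamino group on a six-membered saturated ring and gives 1000 nM. Compound 2, `O=C(Nc1cc2cc[nH]c(=O)c2cc1Cl)[C@H]1CCCN1`, gives 130 nM, and compound 3, `O=C(Nc1cc2cc[nH]c(=O)c2cc1Cl)[C@@H]1CCCN1`, gives 35 nM. Compound 1 thus gives the highest number of the three, so it is the weakest inhibitor shown.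

Among the compounds with values here, the single measured step, a 3.7-fold lower number from compound 2 to compound 3 (0.57 log units; beyond the scatter), rests on the fact that compounds 2 and 3 differ only in the configuration as drawn and concerns a saturated ring carbon in a pyrrolidine, not the ring of compound 1.

Compound 4, `N[C@H]1CC[C@@H](C(=O)Nc2cc3cc[nH]c(=O)c3cc2Cl)CC1`, differs from compound 1 by amino in place of dimethylamino on a saturated ring carbon. Within the data shown here, no measured pair covers this exact replacement, so the step from compound 2 to compound 3 is only a loose guide to how much a change at a saturated ring carbon can move the number in this assay.

A modest improvement is expected, giving an estimated 5.0-fold lower number from compound 1 to compound 4 (0.70 log units; beyond the scatter). Compound 4 is therefore expected to give about 200 nM, with a likely range from 60 nM to 700 nM.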

Compound 4, half-maximal inhibitory concentration: 15 nM
The estimate for compound 4 lay 13-fold (1.12 log units) above the measured number, outside the stated range (below it).
By their numbers in this assay, from the lowest: compound 4; then compound 3; then compound 2; then compound 1.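

Within the data shown here, on this six-membered ring, the choice of group on the saturated ring carbon matters far more than the earlier compounds could show: amino in place of dimethylamino gives a 67-fold lower number from compound 1 to compound 4 (1.82 log units; beyond the scatter) in this assay on the otherwise unchanged compound. The change also reverses the standing of the two amide types, since compound 1 gave a higher number than both pyrrolidin-2-yl compounds, whereas the 4-aminocyclohexyl group gives an 8.7-fold lower number from compound 2 to compound 4 (0.94 log units; beyond the scatter) and also a 2.3-fold lower number from compound 3 to compound 4 (0.37 log units; beyond the scatter) as its comparison with the better of the pair, which makes compound 4 the strongest inhibitor of the four. No measurement shown here explains why this replacement has so large an effect.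

The compounds shown leave open whether methylamino, the group that lies between amino and dimethylamino, would give a number closer to that of compound 1 or that of compound 4. They also leave open whether a hydroxyl group or an aminomethyl group on the same ring carbon could keep the low number, and how the opposite ring configuration of the 4-aminocyclohexyl amide would behave.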